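The source may report more compounds than this note shows. Statements on the series, on what has been measured and on what is new or still open speak of the compounds shown alone.

Working notes on the aryl piperazine series.

Compound 1 `COc1ccc(N2CCN(Cc3csc(N)c3C(=O)c3ccc(Cl)cc3)CC2)cc1` serves as the reference point. In a functional assay on CHO cells with adenosine receptor A1 (Homo sapiens) as the target, read by cAMP accumulation and immunoassay, with a stated time of 6 min, tested at 0.01 uM (a lower number here means a stronger effect, a higher number a weaker effect of the compound at the concentration tested), compound 1 gives -1.2%. On the numbers alone compound 1 stands highest of the three measured compounds, but the gaps to both neighbours fall inside the usual scatter, so no order among them can be read from this. Compound 2 `Nc1scc(CN2CCN(c3ccncc3)CC2)c1C(=O)c1ccc(Cl)cc1` gives -4% in this assay, and compound 3 `Nc1scc(CN2CCN(c3ccc(F)c(F)c3)CC2)c1C(=O)c1ccc(Cl)cc1` gives -3.2%. The three steps are a number 2.8 percentage points lower from compound 1 to compound 2 (within the scatter), a number 2 percentage points lower from compound 1 to compound 3 (within the scatter) and a number 0.8 percentage points higher from compound 2 to compound 3 (within the scatter), each of them within the scatter. Swapping the group on the ring amine nitrogen between 4-methoxyphenyl, pyridin-4-yl and 3,4-difluorophenyl has so far left the read-out essentially flat near zero.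

Compound 4 `Nc1scc(CN2CCN(c3cc(F)cc(F)c3)CC2)c1C(=O)c1ccc(Cl)cc1` is not yet measured. Relative to compound 1 the change is 3,5-difluorophenyl in place of 4-methoxyphenyl on an amine nitrogen in a ring. The step that bears most directly on it is a number 2 percentage points lower from compound 1 to compound 3 (within the scatter), a fluorinated phenyl entering at the same place, and a number 2.8 percentage points lower from compound 1 to compound 2 (within the scatter) points the same way; both were within the scatter. For compound 4 a step of a number 1.8 percentage points lower from compound 1 to compound 4 (within the scatter) is therefore expected, that is none beyond the scatter. Compound 4 is estimated at -3%, with a range from -10% to 5%.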

Compound 4, a percentage reported as activity, at one concentration (the size of the read-out at that concentration, not a potency): -13%
Estimate against measurement, compound 4: 10 percentage points above, outside the stated range (below it).
By their numbers in this assay, from the lowest: compounds 4, 2, 3 and 1 (each within the scatter of the next, the first and the last beyond it).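

The step of a number 11.8 percentage points lower from compound 1 to compound 4 (beyond the scatter) is the first in this series to pass beyond the scatter in this assay, so the group on the ring amine nitrogen is no longer shown as silent, though the effect is modest in size. That separation holds only against the 4-methoxyphenyl of compound 1: the steps to 3,5-difluorophenyl from 3,4-difluorophenyl (a number 9.8 percentage points lower from compound 3 to compound 4 (within the scatter)) and from pyridin-4-yl (a number 9 percentage points lower from compound 2 to compound 4 (within the scatter)) both stay within the scatter, so compound 4 cannot be set apart from compound 3 or compound 2. No measurement at hand offers an explanation for this step.

Open, going by these compounds, is whether the step depends on the fluorine atoms as they sit in 3,5-difluorophenyl, or would also appear with plain phenyl, 3-fluorophenyl or 3,5-dichlorophenyl on the same nitrogen. A read-out at a single concentration also leaves the potency of compound 4 and its neighbours undefined.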